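Chloro for Methoxy Toward a New Benzylurea Analogue

A few compounds are considered here, and "the series" means these few. Any claim that something is new, unique, unknown or untested is made for them only; others in the source may bear on it.

Compound 1, `COc1cnc2ccc(=O)n(CCN3CCC(NC(=S)NCc4ccc(Cl)cc4)CC3)c2c1`, gives 29.5% in an ADME assay on RAW264.7 cells (Mus musculus) for cytotoxicity, read by MTT assay, with a stated time of 48 h, tested at 100 uM; on this read-out lower numbers stand for less inhibition and higher numbers for more inhibition at the one concentration tested (going by the name of the read-out).
Compound 2, `COc1ccc(CNC(=S)NC2CCN(CCn3c(=O)ccc4ncc(OC)cc43)CC2)cc1`, gives 19.4% in this assay.
Compound 3, `COc1ccc(CNC(=O)NC2CCN(CCn3c(=O)ccc4ncc(F)cc43)CC2)cc1`, gives 32.1% in this assay.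

Compound 2 and compound 1 differ in one place, (chloro in place of methoxy on an aromatic carbon), and that step reads a number 10.1 percentage points higher from compound 2 to compound 1 (beyond the scatter). Compound 3 and compound 2 differ in more than one place; the difference between the two cores is not broken down here. Compound 4, `O=C(NCc1ccc(Cl)cc1)NC1CCN(CCn2c(=O)ccc3ncc(F)cc32)CC1`, is not yet measured in this assay. It stands to compound 3 as compound 1 stands to compound 2, (chloro in place of methoxy on an aromatic carbon), the same change at the same place. For compound 4 the expected step is a number 8.9 percentage points higher from compound 3 to compound 4 (within the scatter). For the measured compounds named here, that expectation rests on the single measured example of the change, a number 10.1 percentage points higher from compound 2 to compound 1 (beyond the scatter). Compound 4 is therefore estimated at 41%, with a range from 29% to 54%.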

Compound 4, a percentage reported as inhibition, at one concentration (the size of the read-out at that concentration, not a potency): 42.7%
For compound 4 the middle estimate is 1.7 percentage points below the measured one, and the stated range covers the measured number.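

In this assay, replacing 4-methoxybenzyl with 4-chlorobenzyl gives a number 10.6 percentage points higher from compound 3 to compound 4 (beyond the scatter). Set beside the earlier case, the change carries over from the core of compound 2 to the core of compound 3 at much the same size: the same change on two cores in this assay, a number 10.1 percentage points higher (beyond the scatter) from compound 2 to compound 1 and a number 10.6 percentage points higher (beyond the scatter) from compound 3 to compound 4, 0.5 percentage points apart, within the scatter of two such steps. For the compounds shown here, these are only two pairs, so they do not show that the step would hold on any other core, and they do not explain why the number rises.

The compounds shown leave open whether a bromo or a trifluoromethyl group at the same place, para to a large group, would read as chloro does. They also leave open whether the step would survive a longer chain in place of the benzyl link.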